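This account rests on a few compounds, and the source may have more. Where it says the series, first, only, none or still open, it means among the compounds named here.

In a functional assay on WM 266-4 cells (Homo sapiens) for antiproliferative activity, read by MTT assay, with a stated time of 24 h (a lower number here means a stronger inhibitor of growth, a higher number a weaker inhibitor of growth), two compounds have been measured so far. Compound 1 `c1ccc(N2N=C(c3ccc4c(c3)OCCO4)CC2c2ccco2)cc1` carries a furan-2-yl group on a saturated ring carbon of its core. In this assay compound 1 reaches only a limit, > 100000 nM. Compound 2 `O=C(c1ccc2c(c1)OCCO2)N1N=C(c2ccc(Br)cc2)CC1c1ccccc1F` is built differently, with a carbonyl joining its ring system to the core, and in this assay compound 2 gives 750 nM. Among the measured compounds shown here, no two measured compounds differ in a single place, so no one step can be read from them. Compound 3 `Brc1ccc(C2CC(c3ccc4c(c3)OCCO4)=NN2c2ccccc2)cc1` is the untested partner of compound 1: 4-bromophenyl in place of furan-2-yl on a saturated ring carbon. Compound 2 also carries a 4-bromophenyl group, yet its further differences from compound 3 leave its value as a lone observation. Compound 3 is expected to stay a weak inhibitor, with a step of an at least 2.0-fold lower number from compound 1 to compound 3 (0.30 log units; that floor lies within the scatter) that is likely small. The estimate for compound 3 is 50000 nM, between 10000 nM and 200000 nM.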

Compound 3, concentration for 50% growth inhibition: 3010 nM
For compound 3 the middle estimate is 17-fold (1.22 log units) above the measured one, outside the stated range (below it).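

Among the compounds shown here, this is the first comparison in the set that differs in only one place, and it shows that the group on this saturated ring carbon matters greatly. In this assay, 4-bromophenyl in place of furan-2-yl gives an at least 33-fold lower number from compound 1 to compound 3 (1.52 log units; beyond the scatter), so the same core moves from a limit of the assay to a measurable value. The step gives only a minimum size and not an exact one, because compound 1 stands at a limit rather than at a number: the limit of > 100000 nM in this assay, at which 1 of the 3 values shown sits.

As far as these compounds go, it remains open whether the bromine or the six-membered aromatic ring accounts for the change, a question that a plain phenyl or a 4-chlorophenyl group on the same carbon would help to settle. Compound 2 differs from compound 3 in more than one place, so it cannot answer this question.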